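The source may report more compounds than this note shows. Statements on the series, on what has been measured and on what is new or still open speak of the compounds shown alone.

Compound 1 `O=C(Nc1cccc(Cl)c1)c1ccccc1O`: 37000 nM
Compound 2 `COc1ccccc1C(=O)Nc1cccc(Cl)c1`: > 100000 nM (a limit)
Compound 3 `COc1ccccc1C(=O)Nc1ccccc1`: > 100000 nM (a limit)

These results come from an ADME assay on HEK293 cells (Homo sapiens) for cytotoxicity, read by reporter gene assay and resazurin assay, with a stated time of 48 h; on this read-out lower numbers stand for higher toxicity in this test and higher numbers for lower toxicity in this test. Compound 2 sits at the limit of > 100000 nM in this assay, at which 2 of the 3 values shown sit, so it has a limit and not a number. Compound 4 `COc1ccc(Br)cc1C(=O)Nc1cccc(Cl)c1` differs from it by one change: bromo in place of hydrogen on an aromatic carbon. Among the compounds with values here, no measured step shows a bromo entering. The nearest is a step that the two limits leave unreadable from compound 2 to compound 3, which concerns chloro and hydrogen on an aromatic carbon. The other, an at least 2.7-fold higher number from compound 1 to compound 2 (0.43 log units; beyond the scatter), is a change at an oxygen and says little here. Compound 1, at 37000 nM, shows that a measured number can occur in this series, so only a small expected move toward lower numbers seems fair. The estimated step is an at least 1.1-fold lower number from compound 2 to compound 4 (0.04 log units; that floor lies within the scatter). For compound 4 the expected value is 90000 nM, with an estimated range from 35000 nM to 200000 nM.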

Compound 4, half-maximal cytotoxic concentration: > 100000 nM
Compound 4: a limit, no number; the forecaster's own chance of this, stated with the estimate: 55%; at least 1.1-fold (0.04 log units) between middle value and limit.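

Compound 2 and compound 4 both give a limit rather than a number, so no step can be read between them: the limit of > 100000 nM in this assay, at which 3 of the 4 values shown sit. The compounds shown leave open whether bromo in place of hydrogen shifts cytotoxicity at all.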